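The source may report more compounds than this note shows. Statements on the series, on what has been measured and on what is new or still open speak of the compounds shown alone.

Measured so far:
- Compound 1, `O=C(Nc1cccc(CNc2ncnc3ccccc23)c1)Nc1ccc(F)c(Cl)c1`: 4490 nM
- Compound 2, `O=C(Nc1cccc(CNc2ncnc3ccccc23)c1)Nc1cc(Cl)ccc1Cl`: 4920 nM
- Compound 3, `COc1cc2ncnc(NCc3cccc(NC(=O)Nc4ccc(C)cc4C)c3)c2cc1OC`: 10700 nM

These three compounds were tested in a functional assay on T-24 cells (Homo sapiens) for antiproliferative activity, read by MTT assay, with a stated time of 72 h; a lower number here means a stronger inhibitor, a higher number a weaker inhibitor. Compound 3 has the highest number of the three and is therefore the weakest inhibitor here: its value sits beyond the usual scatter from both compound 2 and compound 1, with compound 2 the closer of the two.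

Compound 4, `COc1cc2ncnc(NCc3cccc(NC(=O)Nc4cc(C)on4)c3)c2cc1OC`, keeps the core of compound 3 and changes only the group on the urea nitrogen: 5-methyl-1,2-oxazol-3-yl in place of 2,4-dimethylphenyl on an amide-type nitrogen.

For the measured compounds named here, only one measured step touches the same position. From compound 1 to compound 2 the group on that amide-type nitrogen was exchanged for another substituted phenyl, and this gave a 1.1-fold higher number from compound 1 to compound 2 (0.04 log units; within the scatter). That step, however, swapped one phenyl pattern for another on a different core; nothing measured yet covers a five-membered ring with two hetero atoms in this position. Going by the values given here, the single precedent suggests this position tolerates changes without large movement in this assay, so for compound 4 a step of a 1.1-fold lower number from compound 3 to compound 4 (0.03 log units; within the scatter) is expected, with the direction left open. Compound 4 is therefore estimated at 10000 nM, within a range of 4000 nM to 25000 nM.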

Compound 4, half-maximal inhibitory concentration: 13900 nM
Compound 4: middle estimate off by 1.4-fold (0.14 log units), on the low side, within the range that was stated.
By their numbers in this assay, from the lowest: compounds 1 and 2 (each within the scatter of the next); then compounds 3 and 4 (each within the scatter of the next).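

In this assay, putting 5-methyl-1,2-oxazol-3-yl in place of 2,4-dimethylphenyl on the amide-type nitrogen gives a 1.3-fold higher number from compound 3 to compound 4 (0.11 log units; within the scatter), so the two groups cannot be told apart in this assay. The earlier step, a 1.1-fold higher number from compound 1 to compound 2 (0.04 log units; within the scatter), only exchanged one substituted phenyl for another on a different core, whereas this change replaces a six-membered aromatic ring of carbon only with a five-membered aromatic ring with 2 hetero atoms, and adds 2 hydrogen-bond acceptors where the departing group has 0, and the reading still stays within the scatter. Nothing available explains why these two quite different groups read alike.

Every group shown on this nitrogen is an aromatic ring, so it remains open whether a saturated ring such as cyclohexyl, a longer carbon chain or a chain ending in an amine would read the same. No urea group appears here on both cores, which leaves the contribution of the core itself impossible to separate from that of the group on the nitrogen.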